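A few compounds are considered here, and "the series" means these few. Any claim that something is new, unique, unknown or untested is made for them only; others in the source may bear on it.

Working notes on the series. Compound 1 `Cc1ccc(C2CC(c3ccc(Cl)cc3)=NN2c2nc3ccc(S(N)(=O)=O)cc3s2)cc1`, compound 2 `NS(=O)(=O)c1ccc2nc(N3N=C(c4ccc(Br)cc4)CC3c3cccs3)sc2c1` and compound 3 `NS(=O)(=O)c1ccc2nc(N3N=C(c4ccc(Cl)cc4)CC3c3cccs3)sc2c1` share one core. In a functional assay on the whole organism (strain Wistar) for inhibition, with Rattus norvegicus as the target, read by paw edema, with stated times of 1 h and 5 h, at a dose of 20 mg/kg by the oral route (on this read-out lower numbers stand for less inhibition and higher numbers for more inhibition at the one dose given (going by the name of the read-out)), compound 1 gives 14%. In this assay compound 2 gives 14%, and compound 3 gives 14%. The change 4-methylphenyl in place of thiophen-2-yl on a saturated ring carbon made the step of no change at the digits printed from compound 3 to compound 1 (within the scatter). The cores of compound 2 and compound 3 differ by bromo in place of chloro on an aromatic carbon, which gave no change at the digits printed from compound 2 to compound 3 (within the scatter). Compound 4 `Cc1ccc(C2CC(c3ccc(Br)cc3)=NN2c2nc3ccc(S(N)(=O)=O)cc3s2)cc1` has not yet been measured. Among the measured compounds shown here, the change 4-methylphenyl in place of thiophen-2-yl on a saturated ring carbon is the same kind of change as the one from compound 3 to compound 1; the places differ only in that the ring atom two ring bonds away bears a 4-bromophenyl group in compound 2 and a 4-chlorophenyl group in compound 3. The step from compound 2 to compound 4 is expected to be no change at the digits printed from compound 2 to compound 4 (within the scatter) because the like change gave no change at the digits printed from compound 3 to compound 1 (within the scatter). Compound 4 is expected to give 14%, with the range 6% to 24%.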

Compound 4, a percentage reported as inhibition, in the whole organism at one dose (the size of the read-out at that dose, not a potency): 14%
The estimate for compound 4 equals the measured number at the digits printed; low and high end bracket the measured number.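

Carrying 4-methylphenyl in place of thiophen-2-yl from one core to the other holds in this assay: the same change on two cores in this assay, no change at the digits printed (within the scatter) from compound 3 to compound 1 and no change at the digits printed (within the scatter) from compound 2 to compound 4, 0 percentage points apart, within the scatter of two such steps

Bromo in place of chloro on an aromatic carbon carries over in the same way: the same change on two cores in this assay, no change at the digits printed (within the scatter) from compound 2 to compound 3 and no change at the digits printed (within the scatter) from compound 4 to compound 1, 0 percentage points apart, within the scatter of two such steps

With no change at the digits printed from compound 2 to compound 4 (within the scatter) and no change at the digits printed from compound 1 to compound 4 (within the scatter), what carries over is only the absence of a step, so this does not show how a change with a step beyond the scatter would transfer between these cores, and a single dose gives no potency.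

The compounds shown leave open whether paw edema inhibition can be moved at all by changes at these places. An amine or a carboxylic acid in place of 4-methylphenyl on the saturated ring carbon would test this.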